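Cyclopentyl in place of 1-propylbutyl on the ring nitrogen

The source may hold more compounds than are shown below. What is called first, only, known or untested is meant among the compounds shown, and "the series" means these compounds.

Measured so far:
compound 1 `CCCC(CCC)n1c(-c2ccc(OCc3c(-c4c(Cl)cccc4Cl)noc3C(C)C)cc2)nc2ccc(C(=O)O)cc21`: > 10000 nM
compound 2 `CCC(CC)n1c(-c2ccc(OCc3c(-c4c(Cl)cccc4Cl)noc3C(C)C)cc2Cl)nc2ccc(C(=O)O)cc21`: 1010 nM

In an assay on HEK-293T cells for antagonist activity at vitamin D3 receptor (Homo sapiens), read by a luciferase reporter, with a stated time of 24 h (on this read-out higher numbers stand for weaker inhibition and lower numbers for stronger inhibition), compound 1 gives only a limit, > 10000 nM; it sits at the limit of > 10000 nM in this assay, at which 1 of the 2 values shown sits. Differing from compound 1 in two places, compound 2 gives 1010 nM in this assay, so no single step between measured compounds is available. Compound 3 `CC(C)c1onc(-c2c(Cl)cccc2Cl)c1COc1ccc(-c2nc3ccc(C(=O)O)cc3n2C2CCCC2)cc1` is not yet measured. It differs from compound 1 by cyclopentyl in place of 1-propylbutyl on an aromatic nitrogen. With compound 1 known only as a limit, the step from compound 1 to compound 3 is expected to be toward stronger inhibition, an at least 2.8-fold lower number from compound 1 to compound 3 (0.45 log units; beyond the scatter), though it may not exceed the scatter. For compound 3 the estimate is 3500 nM, between 900 nM and 12000 nM.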

Compound 3, half-maximal inhibitory concentration: 929 nM
The estimate for compound 3 lay 3.8-fold (0.58 log units) above the measured number; measured number inside the range.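

In this assay, the group on the aromatic nitrogen can move the read-out on its own: cyclopentyl in place of 1-propylbutyl gives an at least 10-fold lower number from compound 1 to compound 3 (1.03 log units; beyond the scatter). Compound 1 gives > 10000 nM, which is a limit and not a number. The step therefore gives only a bound on the change, because compound 1 stands at that limit: the limit of > 10000 nM in this assay, at which 1 of the 3 values shown sits.

From the compounds shown here alone, whether the ring or the change in carbon count carries the step stays open, since the two change together here. Cyclohexyl on the same nitrogen would add a further point on this.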